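The source may report more compounds than this note shows. Statements on the series, on what has been measured and on what is new or still open speak of the compounds shown alone.

Of the compounds shown here, three that share one core have been measured in an assay on HEK293 cells for agonist activity at transient receptor potential cation channel subfamily M member 8 (Homo sapiens), read by fluorescence and calcium flux, with a stated time of 15 min; a higher number here means that more compound is needed for the effect, a lower number that less compound is needed. Compound 1 `C=CCN(Cc1cccs1)C(=O)COc1ccc(C)cc1` gives 20 nM. Compound 2 `CCN(Cc1cccnc1)C(=O)COc1ccc(C)cc1` differs from compound 1 in two places at once; compound 2 gives 15400 nM. Compound 3 `CON(Cc1cccs1)C(=O)COc1ccc(C)cc1` gives 10 nM, the lowest of the three numbers; its gap to compound 1 lies within the scatter, while its gap to compound 2 lies far beyond it, so compound 3 cannot be ranked against compound 1.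

Compound 4 `CCN(Cc1cccs1)C(=O)COc1ccc(C)cc1` has not yet been measured. It differs from compound 3 by ethyl in place of methoxy on an amide-type nitrogen. Going by the values given here, only one measured step changes a group on the amide-type nitrogen, and that step, a 2.0-fold lower number from compound 1 to compound 3 (0.30 log units; within the scatter), stayed within the scatter. Compound 2 also carries an ethyl on the amide-type nitrogen, but it differs from compound 1 in a second place as well, so its high number cannot be laid on the ethyl alone. Among the compounds with values here, since the one comparable swap of a small group on this nitrogen left the number essentially unchanged, the number for compound 4 is expected to shift only by a 1.5-fold higher number from compound 3 to compound 4 (0.18 log units; within the scatter), within the scatter. Compound 4 is therefore estimated at 15 nM, with a range from 5 nM to 45 nM.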

Compound 4, half-maximal effective concentration: 8 nM
For compound 4 the middle estimate is 1.9-fold (0.27 log units) above the measured one; the measured number falls inside the stated range.
By their numbers in this assay, from the lowest: compounds 4, 3 and 1 (each within the scatter of the next, the first and the last beyond it); then compound 2.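

Swapping methoxy for ethyl on the amide-type nitrogen gives a 1.3-fold lower number from compound 3 to compound 4 (0.10 log units; within the scatter) in this assay, so two groups of 2 heavy atoms each, only one of which, methoxy, carries a hydrogen-bond acceptor, cannot be told apart here. The comparison with the allyl compound gives the first step on this nitrogen that can be read, a 2.5-fold lower number from compound 1 to compound 4 (0.40 log units; beyond the scatter), a modest step made by methyl in place of vinyl on the saturated chain carbon, although compound 3 stays within the scatter of both of these compounds. The ethyl group is now shared by both members of one pair, and thiophen-2-yl in place of pyridin-3-yl gives a 1900-fold lower number from compound 2 to compound 4 (3.28 log units; beyond the scatter), which ties the very high number of compound 2 to that ring change and not to the ethyl. The data shown offer no measurement that explains any of these steps.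

The compounds shown leave open whether a longer chain such as butyl, or a chain ending in an amine, on the amide-type nitrogen would keep the number this low. They also leave open how a carboxylic acid on the ring carrying the methyl group would affect it.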